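Thiocyanate analogues: removing the para-bromo substituent

A few compounds are considered here, and "the series" means these few. Any claim that something is new, unique, unknown or untested is made for them only; others in the source may bear on it.

Of the compounds shown here, three with the same core have been measured. Compound 1 `O=Cc1c(-c2ccccc2)nc2sc(Cc3ccc(Cl)cc3)nn12` gives 20000 nM in a functional assay on L1210 cells (Mus musculus) for cytotoxicity, with a stated time of 48 h; a lower number here means a stronger inhibitor, a higher number a weaker inhibitor. Compound 2 `N#CSc1c(-c2ccc(F)cc2)nc2sc(Cc3ccc(Cl)cc3)nn12` gives 23000 nM, and compound 3 `N#CSc1c(-c2ccc(Br)cc2)nc2sc(Cc3ccc(Cl)cc3)nn12` gives 81000 nM, the highest of the three numbers. Within the data shown here, the only step that differs in one place, a 3.5-fold higher number from compound 2 to compound 3 (0.55 log units; beyond the scatter), bears on the change now considered. Compound 4 `N#CSc1c(-c2ccccc2)nc2sc(Cc3ccc(Cl)cc3)nn12` differs from compound 3 by hydrogen in place of bromo on an aromatic carbon. Since the fluoro analogue compound 2 reads lower than compound 3 by a 3.5-fold higher number from compound 2 to compound 3 (0.55 log units; beyond the scatter), a similar lower number is expected when the bromo is removed altogether, an estimated step of a 3.2-fold lower number from compound 3 to compound 4 (0.51 log units; beyond the scatter). Compound 4 is therefore estimated at 25000 nM, within a range of 8000 nM to 80000 nM.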

Compound 4, half-maximal inhibitory concentration: 24000 nM
The estimate for compound 4 lay 1.0-fold (0.02 log units) above the measured number; measured number inside the range.
By their numbers in this assay, from the lowest: compounds 1, 2 and 4 (each within the scatter of the next); then compound 3.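

In this assay hydrogen in place of bromo gives a 3.4-fold lower number from compound 3 to compound 4 (0.53 log units; beyond the scatter) while hydrogen in place of fluoro gives a 1.0-fold higher number from compound 2 to compound 4 (0.02 log units; within the scatter) and so, on this aromatic carbon, bromo alone stands apart from the other two. With the phenyl group unsubstituted, cyanosulfanyl in place of formyl gives a 1.2-fold higher number from compound 1 to compound 4 (0.08 log units; within the scatter) and so these two groups cannot be told apart here. Nothing available explains why only the bromo compound stands apart.

As far as these compounds go, whether a methoxy group or an amine on the same aromatic carbon would read with hydrogen and fluoro or with bromo remains open. So does the effect of a carboxylic acid in place of the cyanosulfanyl group.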